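The compounds below may be only part of what the source reports. "The series", "measured", "known", "first", "only" and "open" are said of these compounds alone.

Among the measured compounds shown here, in a functional assay on the whole organism with Mus musculus as the target (on this read-out lower numbers stand for an effect already at smaller amounts and higher numbers for an effect only at larger amounts of compound), only three compounds have values so far. Compound 1 `CS(=O)(=O)c1ccc(C(=O)CC2CCN(Cc3ccccc3)CC2)cc1` gives > 30 mg/kg, which is a limit of the assay and not a number. Compound 2 `Nc1ccc(C(=O)CC2CCN(CC3CC3)CC2)cc1` gives a true number, 10 mg/kg. Compound 3 `CSc1ccc(C(O)CC2CCN(Cc3ccccc3)CC2)cc1` gives > 30 mg/kg, again a limit. Compound 3 therefore stands at the limit of > 30 mg/kg in this assay, at which 2 of the 3 values shown sit, so its actual position is not known.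

The next compound to be measured is compound 4 `OC(CC1CCN(Cc2ccccc2)CC1)c1ccco1`. It has furan-2-yl in place of 4-(methylsulfanyl)phenyl on a saturated chain carbon bound to an oxygen on a saturated carbon and a saturated chain carbon, and the counted difference is furan-2-yl in place of 4-(methylsulfanyl)phenyl on a saturated chain carbon bound to an oxygen on a saturated carbon and a saturated chain carbon.

For the measured compounds named here, no measured pair in this small set shows this exchange, and a limit gives no firm starting point for a step. The expectation in this assay is therefore cautious, with no step beyond the usual scatter and no favoured direction. The expected size of this change is a number no higher from compound 3 to compound 4 (the limit leaves the size open). For compound 4 the estimated value is 30 mg/kg, with an expected range from 10 mg/kg to 100 mg/kg.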

Compound 4, dose for half-maximal effect: > 30 mg/kg
Compound 4 ended at the assay's limit; the forecaster's own chance of this, stated with the estimate: 55%; the middle value sits exactly at the limit.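

In this assay compound 3 gives > 30 mg/kg, a limit of the assay and not a number. Among the compounds shown here, compound 4 gives > 30 mg/kg, also a limit, so no step between compound 3 and compound 4 can be read. The compounds shown leave open whether furan-2-yl in place of 4-(methylsulfanyl)phenyl changes the effect at all, and where the compounds at the limit actually stand: the limit of > 30 mg/kg in this assay, at which 3 of the 4 values shown sit.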